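The source may report more compounds than this note shows. Statements on the series, on what has been measured and on what is new or still open speak of the compounds shown alone.

Compound 1 `COc1cc(-c2cc(/C=C/C(=O)c3ccc(Cl)c(Cl)c3)[nH]n2)cc(OC)c1OC` and compound 2 `COc1ccc(C(=O)/C=C/c2cc(-c3cc(OC)c(OC)c(OC)c3)n[nH]2)cc1` share one core and differ only in the aryl group attached to a carbonyl carbon. In a functional assay on OVCAR-8 cells (Homo sapiens) for inhibition, read by sulforhodamine B assay, with a stated time of 48 h (on this read-out lower numbers stand for stronger inhibition of growth and higher numbers for weaker inhibition of growth), compound 1 gives 6300 nM, while compound 2 gives 2430 nM, the lowest of the two numbers measured; the step of a 2.6-fold lower number from compound 1 to compound 2 (0.41 log units; beyond the scatter) is modest yet beyond the scatter. Compound 3 `COc1cc(-c2cc(/C=C/C(=O)c3ccc(F)c(F)c3)[nH]n2)cc(OC)c1OC` is reached from compound 2 by a single change: 3,4-difluorophenyl in place of 4-methoxyphenyl on a carbonyl carbon. Going by the values given here, the only measured step that bears on this is a 2.6-fold lower number from compound 1 to compound 2 (0.41 log units; beyond the scatter), which linked a 3,4-dichlorophenyl to the 4-methoxyphenyl. Since compound 3 returns to a dihalogenated ring resembling that of compound 1, a modest rise in the number is expected, estimated as a 1.9-fold higher number from compound 2 to compound 3 (0.27 log units; within the scatter), because that is roughly the reverse of a 2.6-fold lower number from compound 1 to compound 2 (0.41 log units; beyond the scatter). Compound 3 is therefore expected to give about 4500 nM, with a plausible range from 1800 nM to 11000 nM.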

Compound 3, concentration for 50% growth inhibition: 2880 nM
Estimate against measurement, compound 3: 1.6-fold (0.19 log units) above, and the stated range covers the measured number.
By their numbers in this assay, from the lowest: compounds 2 and 3 (each within the scatter of the next); then compound 1.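

In this assay, swapping the ring on this carbonyl carbon gives a 1.2-fold higher number from compound 2 to compound 3 (0.07 log units; within the scatter), so 3,4-difluorophenyl and 4-methoxyphenyl cannot be told apart here. The two rings with two halogens do differ, with a 2.2-fold lower number from compound 1 to compound 3 (0.34 log units; beyond the scatter), which shows that carrying two halogens does not by itself set the number at this position: the identity of the halogen matters, and 3,4-dichlorophenyl stands apart from the other two groups. Nothing available explains this difference.

The compounds shown leave open how this position responds to a ring with a single halogen, a plain phenyl ring, or a ring bearing an amine or a carboxylic acid. Going by these compounds alone, with only three groups compared, they also cannot show whether any broader trend holds across this position.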